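Shortening the Phenoxyalkyl Chain toward Compound 3

The source may hold more compounds than are shown below. What is called first, only, known or untested is meant among the compounds shown, and "the series" means these compounds.

Three compounds share one core and differ only in the length of the saturated chain that ends in a phenoxy group. Compound 1 `O=C(O)c1csc([C@H]2CC[C@@H]3[C@@H](CCCCCOc4ccccc4)[C@H](O)C[C@@H]3O2)n1` carries the longest chain; in a functional assay on CHO cells for agonist activity at prostaglandin E2 receptor EP1 subtype (Homo sapiens), read by fluorescence and calcium flux (on this read-out lower numbers stand for an effect already at smaller amounts and higher numbers for an effect only at larger amounts of compound), its entry reads "not determined" (no result reported), so no number exists for it. Compound 2 `O=C(O)c1csc([C@H]2CC[C@@H]3[C@@H](CCCOc4ccccc4)[C@H](O)C[C@@H]3O2)n1` carries a shorter chain, and in this assay compound 2 gives 4200 nM. Going by the values given here, this is the only number in hand, so compound 2 stands alone and cannot be placed above or below any other compound. Compound 3 `O=C(O)c1csc([C@H]2CC[C@@H]3[C@@H](CCOc4ccccc4)[C@H](O)C[C@@H]3O2)n1` has not been measured; it differs from compound 2 by phenoxy in place of phenoxymethyl on a saturated chain carbon, two bonds along the chain from a saturated ring carbon. Among the compounds with values here, no step between two measured compounds is available, so the expectation rests on the single value of compound 2 and on the change itself. In this assay the expected change is a 2.1-fold higher number from compound 2 to compound 3 (0.33 log units; beyond the scatter), a shift beyond the scatter toward an effect only at larger amounts. Compound 3 is estimated at 9000 nM, with a range from 2500 nM to 30000 nM.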

Compound 3, half-maximal effective concentration: 97 nM
Compound 3: middle estimate off by 93-fold (1.97 log units), on the high side, outside the stated range (below it).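

Exchanging phenoxymethyl for phenoxy gives in this assay a 43-fold lower number from compound 2 to compound 3 (1.64 log units; beyond the scatter), a large step well beyond the scatter. Going by these compounds alone, the single value for compound 2 could not show how much this position matters, but this step shows that the response is highly sensitive to the chain here, even with the shared core and the terminal aromatic ring unchanged. The shorter chain of the pair goes with an effect at much smaller amounts, but no measurement at hand explains why so small a change has so large an effect.

Going by these compounds, this is one step between two compounds, and the entry for compound 1 reads "not determined" (no result reported), so it remains open whether the response changes steadily with chain length or whether this chain length is a special case. Also open, on these data alone, is how a still shorter chain, or an amine in place of the chain oxygen, would behave in this assay.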